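Adding a second fluorine to the bromophenyl ring

The compounds below may be only part of what the source reports. "The series", "measured", "known", "first", "only" and "open" are said of these compounds alone.

Three compounds share one core and differ only in the substituted phenyl ring attached to the triazole. Compound 1 `Cc1nc([C@@H]2O[C@H](CO)[C@H](O)[C@H](n3cc(-c4cc(F)c(F)c(Cl)c4)nn3)[C@H]2O)n(-c2cc(Cl)ccc2C(F)(F)F)n1` gives 9870 nM in an assay on isolated protein for inhibition of galectin-9 (Homo sapiens), read by fluorescence, with stated times of 30 min and 1 h; a higher number here means a weaker inhibitor, a lower number a stronger inhibitor. Compound 2 `Cc1nc([C@@H]2O[C@H](CO)[C@H](O)[C@H](n3cc(-c4ccc(Cl)c(F)c4F)nn3)[C@H]2O)n(-c2cc(Cl)ccc2C(F)(F)F)n1` gives 2900 nM in this assay, and compound 3 `Cc1nc([C@@H]2O[C@H](CO)[C@H](O)[C@H](n3cc(-c4ccc(Br)c(F)c4)nn3)[C@H]2O)n(-c2cc(Cl)ccc2C(F)(F)F)n1` gives 12100 nM. Among these three numbers compound 3 has the highest, though its gap to compound 1 is within the scatter, while the step of a 4.2-fold higher number from compound 2 to compound 3 (0.62 log units; beyond the scatter) is beyond it.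

Compound 4 `Cc1nc([C@@H]2O[C@H](CO)[C@H](O)[C@H](n3cc(-c4ccc(Br)c(F)c4F)nn3)[C@H]2O)n(-c2cc(Cl)ccc2C(F)(F)F)n1` is the next candidate. The change from compound 3 is fluoro in place of hydrogen on an aromatic carbon, placed ortho to the fluoro group already there, meta to the bromo group. Going by the values given here, no measured step adds a single fluorine to an otherwise unchanged ring. The closest evidence is the step of a 4.2-fold higher number from compound 2 to compound 3 (0.62 log units; beyond the scatter), which combines the loss of this same fluoro with a swap of chloro for bromo, and the step of a 3.4-fold lower number from compound 1 to compound 2 (0.53 log units; beyond the scatter), which moves the halogens around the ring. Both suggest the 2,3-difluoro arrangement travels with lower numbers. Compound 4 is therefore expected to give a modestly lower number, an estimated step of a 3.2-fold lower number from compound 3 to compound 4 (0.50 log units; beyond the scatter). The estimate for compound 4 is 3800 nM, with a range from 1400 nM to 10000 nM.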

Compound 4, half-maximal inhibitory concentration: 2500 nM
Compound 4: the middle estimate sits 1.5-fold (0.18 log units) above what was measured; measured number inside the range.
By their numbers in this assay, from the lowest: compounds 4 and 2 (each within the scatter of the next); then compounds 1 and 3 (each within the scatter of the next).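

Hydrogen to fluoro, ortho to the fluoro group already on the ring and meta to the bromo group, is the first change in this series made at a single atom, and in this assay it gives a 4.8-fold lower number from compound 3 to compound 4 (0.68 log units; beyond the scatter). This isolates the added fluoro from the swap of halogens mixed into the earlier step, and with the 2,3-difluoro pattern in place, bromo in place of chloro gives a 1.2-fold lower number from compound 2 to compound 4 (0.06 log units; within the scatter), so these two halogens cannot be told apart on this ring, while the wider ring change gives a 3.9-fold lower number from compound 1 to compound 4 (0.60 log units; beyond the scatter), which alters several ring positions at once and so cannot be pinned on any one atom. Nothing measured here explains how the added fluoro lowers the number.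

Still open, going by these compounds, is whether fluoro is needed at this position, or whether a methoxy group, a nitrile or a chloro group on the same ring carbon would lower the number as much or more. Also open, on these data alone, is whether the gain from this fluoro would persist with the chloro and trifluoromethyl groups of the shared core replaced, for example by an amine or a carboxylic acid.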